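This account rests on a few compounds, and the source may have more. Where it says the series, first, only, none or still open, it means among the compounds named here.

Measured in an ADME assay on BaF3 cells (Mus musculus) for antiproliferative activity, read by CCK-8 assay, with a stated time of 72 h; a higher number here means a weaker inhibitor of growth, a lower number a stronger inhibitor of growth:
- compound 1 `O=C(CCSc1ccc2c(/C=C/c3ccccn3)n[nH]c2c1)Nc1ccc(F)c(C(F)(F)F)c1`: 610 nM
- compound 2 `O=C(CCSc1ccc2c(/C=C/c3ccccn3)n[nH]c2c1)Nc1ccc(Cl)c(C(F)(F)F)c1`: > 10000 nM, a limit of the assay and not a number
- compound 3 `Cc1ccc(NC(=O)CCSc2ccc3c(/C=C/c4ccccn4)n[nH]c3c2)cc1C(F)(F)F`: 530 nM

Compound 3 lies within the scatter of compound 1 and far from the limit of compound 2: an at least 18-fold lower number from compound 2 to compound 3 (1.27 log units; beyond the scatter).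

Compound 4 `COc1ccc(NC(=O)CCSc2ccc3c(/C=C/c4ccccn4)n[nH]c3c2)cc1C(F)(F)F` makes one change to compound 3: methoxy in place of methyl on an aromatic carbon. Among the compounds with values here, no measured step places methoxy on this carbon, but two steps swap the group there. Methyl in place of fluoro gave a 1.2-fold lower number from compound 1 to compound 3 (0.06 log units; within the scatter), whereas chloro in place of fluoro gave an at least 16-fold higher number from compound 1 to compound 2 (1.21 log units; beyond the scatter). A swap at this carbon can therefore be harmless or costly. A moderately higher number is expected in this assay, as a 2.3-fold higher number from compound 3 to compound 4 (0.35 log units; beyond the scatter). Compound 4 is estimated at 1200 nM, with an expected range from 300 nM to 8000 nM.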

Compound 4, concentration for 50% growth inhibition: > 10000 nM
Compound 4 gave a limit, no number (the forecaster's own chance of this, stated with the estimate: 20%); middle value at least 8.3-fold (0.92 log units) away from the limit.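

In this assay, methoxy on this carbon, para to a large group, falls on the costly side of the swaps, as chloro did: an at least 18-fold higher number from compound 3 to compound 4 (1.27 log units; beyond the scatter), and an at least 16-fold higher number from compound 1 to compound 4 (1.21 log units; beyond the scatter). Compound 4 sits at a limit of the assay, > 10000 nM, and not at a number. The step between compound 2 and compound 4 cannot be read, since both stop at the same limit: the limit of > 10000 nM in this assay, at which 2 of the 4 values shown sit.

The compounds shown leave open whether the oxygen of methoxy or its added heavy atom matters more. An ethyl group or a hydroxyl on this carbon would help separate the two.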